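Replacing hydroxy with methylamino on the amide side chain

The source may report more compounds than this note shows. Statements on the series, on what has been measured and on what is new or still open speak of the compounds shown alone.

Measured in a functional assay on HeLa cells (Homo sapiens) for antiproliferative activity, read by MTT assay, with a stated time of 48 h; a higher number here means a weaker inhibitor, a lower number a stronger inhibitor:
- compound 1 `COc1ccc(C(=O)c2ccc(OC)c3c2C=CC(C)(C)O3)c(NC(=O)CO)c1`: 310 nM
- compound 2 `COc1ccc(C(=O)c2ccc3c(c2)C=CC(C)(C)O3)c(NC(=O)CN)c1`: 580 nM

Only these two values are available, and they lie within the scatter of each other, so compound 1 stands level with compound 2 and no order can be read between them. Among the compounds with values here, no step between measured compounds that differ in one place is available, so the size of this exchange has not been measured directly.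

The next compound is compound 3 `CNCC(=O)Nc1cc(OC)ccc1C(=O)c1ccc(OC)c2c1C=CC(C)(C)O2`, which differs from compound 1 as follows: methylamino in place of hydroxy on a saturated chain carbon bound to a carbonyl carbon. This places methylamino in place of hydroxy on a saturated chain carbon bound to a carbonyl carbon, and the hydrogen-bond count stays the same.

Within the data shown here, with compound 1 at 310 nM and compound 2 at 580 nM as the only guide, no shift beyond the scatter is expected in this assay, and any small drift is expected towards a higher number. The expected change is a 1.3-fold higher number from compound 1 to compound 3 (0.11 log units; within the scatter), which is an estimate and stays within the scatter. For compound 3 the estimated value is 400 nM, with an expected range from 130 nM to 1200 nM.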

Compound 3, half-maximal inhibitory concentration: 2170 nM
For compound 3 the middle estimate is 5.4-fold (0.73 log units) below the measured one; measured number above the stated range.
By their numbers in this assay, from the lowest: compounds 1 and 2 (each within the scatter of the next); then compound 3.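

In this assay, within the data shown here, the saturated chain carbon bound to a carbonyl carbon does not tolerate every exchange equally: methylamino in place of hydroxy gives a 7.0-fold higher number from compound 1 to compound 3 (0.85 log units; beyond the scatter), the first direct reading of a single change at this place. The hydrogen-bond donor and acceptor counts stay the same across this exchange, so those counts alone do not track the value at this position in this pair. Compound 2 differs from compound 1 in more than one place, so the earlier pair could not isolate this effect, and nothing available here accounts for the step.

Going by these compounds, the step rests on one pair on the core of compound 1, and whether it follows the nitrogen or the added carbon remains open; methoxy or dimethylamino on the same chain carbon would help separate the two. Also open, on these data alone, is whether a longer chain carrying hydroxy, or a carboxylic acid at this place, would keep a number near that of compound 1 at 310 nM or move with compound 3 at 2170 nM.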